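The source may hold more compounds than are shown below. What is called first, only, known or untested is meant among the compounds shown, and "the series" means these compounds.

Measured compounds:
compound 1, `CC1(C)OC(=O)C2(C(=O)O1)[C@@H](c1ccc(-c3ccc(O)cc3)cc1)CC(=O)C[C@H]2c1ccccc1`, 9000 nM
compound 2, `CC1(C)OC(=O)C2(C(=O)O1)[C@@H](c1ccc(-c3ccc(CO)cc3)cc1)CC(=O)C[C@H]2c1ccccc1`, 38000 nM
compound 3, `Oc1ccc(-c2cc(O)cc(O)c2)cc1`, a limit of the assay only, > 80000 nM

These values come from a functional assay on K562 cells (Homo sapiens) for antiproliferative activity, read by trypan blue exclusion, with a stated time of 48 h; a lower number here means a stronger inhibitor, a higher number a weaker inhibitor. Compound 1 and compound 2 differ by hydroxymethyl in place of hydroxy on an aromatic carbon; this change gave a 4.2-fold higher number from compound 1 to compound 2 (0.63 log units; beyond the scatter). For compound 3 the assay reports only a limit, (the limit of > 80000 nM in this assay, at which 1 of the 3 values shown sits). The difference between the core of compound 3 and the core of compound 1 is not broken down here. Compound 4, `OCc1ccc(-c2cc(O)cc(O)c2)cc1`, is not yet measured; it differs from compound 3 by hydroxymethyl in place of hydroxy on an aromatic carbon, the same kind of change, though here the place is para to a group of 8 heavy atoms, where in compound 1 it is para to a large group. Because compound 3 already sits at the limit of > 80000 nM in this assay, at which 1 of the 3 values shown sits, and the earlier step of a 4.2-fold higher number from compound 1 to compound 2 (0.63 log units; beyond the scatter) raised the number, compound 4 is expected to remain at or beyond that limit in this assay, the step being estimated as a step that the limit leaves unreadable from compound 3 to compound 4. Compound 4 is therefore estimated at 200000 nM.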

Compound 4, half-maximal inhibitory concentration: > 80000 nM
Compound 4 ended at the assay's limit; the forecaster's own chance of this, stated with the estimate: 85%; the middle value is on the limit's open side.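

Compound 3 and compound 4 both stand only at a limit in this assay, so no step can be read between them: the limit of > 80000 nM in this assay, at which 2 of the 4 values shown sit.

The compounds shown leave open whether hydroxymethyl in place of hydroxy changes the number at all on the core of compound 3.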